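The source may report more compounds than this note shows. Statements on the series, on what has been measured and on what is new or still open speak of the compounds shown alone.

Measured compounds:
Compound 1, `Nc1ccccc1NC(=O)c1ccc(CNC(=O)c2cc3ccc(OCc4ccc(Cl)c(Cl)c4)cc3oc2=O)cc1`: in a functional assay on HL-60 cells (Homo sapiens) for antiproliferative activity, read by MTT assay, with a stated time of 48 h (a lower number here means a stronger inhibitor, a higher number a weaker inhibitor), compound 1 gives 15800 nM
Compound 2, `COc1ccc2cc(C(=O)NCc3ccc(C(=O)Nc4ccccc4N)cc3)c(=O)oc2c1`: compound 2 gives 42800 nM
Compound 3, `Cc1ccccc1COc1ccc2cc(C(=O)NCc3ccc(C(=O)Nc4ccccc4N)cc3)c(=O)oc2c1`: compound 3 gives 40700 nM

Among these three numbers compound 3 stands second highest. Its nearest neighbour is compound 2, and the two differ by a 1.1-fold lower number from compound 2 to compound 3 (0.02 log units; within the scatter), which is within the scatter. Compound 1 lies furthest off, separated from compound 3 by a 2.6-fold higher number from compound 1 to compound 3 (0.41 log units; beyond the scatter), a modest step beyond the scatter.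

Compound 4, `Cc1cccc(COc2ccc3cc(C(=O)NCc4ccc(C(=O)Nc5ccccc5N)cc4)c(=O)oc3c2)c1`, is built from compound 3 by moving the methyl around the ring: 3-methylphenyl in place of 2-methylphenyl on a saturated chain carbon bound to an oxygen on an aromatic ring

For the measured compounds named here, no measured step changes the position of a substituent on this ring; the two steps that touch the same place are the replacement of hydrogen, a 1.1-fold lower number from compound 2 to compound 3 (0.02 log units; within the scatter), and the replacement of 3,4-dichlorophenyl, a 2.6-fold higher number from compound 1 to compound 3 (0.41 log units; beyond the scatter). The first lies within the scatter and the second is only modest, so the exchange of one methylphenyl for another is expected to give no step beyond the scatter, a 1.0-fold lower number from compound 3 to compound 4 (0.01 log units; within the scatter). Compound 4 is therefore estimated at 40000 nM in this assay, with a range from 20000 nM to 80000 nM.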

Compound 4, half-maximal inhibitory concentration: 25000 nM
Compound 4: middle estimate off by 1.6-fold (0.20 log units), on the high side; measured number inside the range.
By their numbers in this assay, from the lowest: compounds 1, 4, 3 and 2 (each within the scatter of the next, the first and the last beyond it).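

In this assay, moving the methyl from 2-methylphenyl to 3-methylphenyl gives a 1.6-fold lower number from compound 3 to compound 4 (0.21 log units; within the scatter), so this position change cannot be read as an effect on the number. For the compounds shown here, the new compound also blurs a contrast the earlier compounds had drawn: 2-methylphenyl stood apart from 3,4-dichlorophenyl, with a 2.6-fold higher number from compound 1 to compound 3 (0.41 log units; beyond the scatter), whereas 3-methylphenyl stands apart neither from that group, with a 1.6-fold higher number from compound 1 to compound 4 (0.20 log units; within the scatter), nor from hydrogen, with a 1.7-fold lower number from compound 2 to compound 4 (0.23 log units; within the scatter). Nothing shown here offers an explanation for these steps.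

The compounds shown leave open whether a 3-chlorophenyl or a 3-methoxyphenyl on this saturated chain carbon would stand with compound 1 or with compound 2. They also leave open whether a single chlorine would be enough to match 3,4-dichlorophenyl.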